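This account rests on a few compounds, and the source may have more. Where it says the series, first, only, none or still open, it means among the compounds named here.

The study concerns a small set of purine-based compounds that carry a chloromethylbenzyl group on the nitrogen of the shared core, and measures their effect on tumour cell growth in a functional assay on COLO 205 cells (Homo sapiens) for cytotoxicity, read by sulforhodamine B assay, with a stated time of 48 h; a higher number here means a weaker inhibitor of growth, a lower number a stronger inhibitor of growth. Compound 1 `Nc1nc(Cl)c2ncn(Cc3ccccc3CCl)c2n1` carries an amino group on the core beside the chloro, and in this assay compound 1 gives 5010 nM. Compound 2 `ClCc1ccc(Cn2cnc3c(Cl)nc(Cl)nc32)cc1` bears two chloro groups on the core instead, and in this assay compound 2 gives 3470 nM. These two values lie within the usual scatter of each other, so no order between compound 1 and compound 2 can be claimed.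

Compound 3 `ClCc1ccccc1Cn1cnc2c(Cl)nc(Cl)nc21` combines the dichlorinated core of compound 2 with the chloromethylbenzyl group of compound 1; for compound 3 the result in this assay is "not determined" (no result reported), so it stands without a number of its own.

Compound 4 `ClCc1ccccc1Cn1cnc2c(Cl)ncnc21` is the direct descendant of compound 3 and differs from it by a single change: hydrogen in place of chloro on an aromatic carbon. Among the compounds with values here, no measured pair shows the effect of this change, so its size cannot be read from the data. Given that compound 1 gave 5010 nM and compound 2 gave 3470 nM, the whole set appears to cluster in the low-micromolar range, and a shift beyond the scatter in either direction is not expected. Compound 4 is therefore estimated at 5000 nM, with a range of 1500 nM to 16000 nM.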

Compound 4, concentration for 50% growth inhibition: 3890 nM
Beside the measured number, compound 4's estimate is 1.3-fold (0.11 log units) above it; the range from low to high includes it.
By their numbers in this assay, from the lowest: compounds 2, 4 and 1 (each within the scatter of the next).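

Hydrogen in place of amino, on the aromatic carbon between two ring nitrogen atoms, gives a 1.3-fold lower number from compound 1 to compound 4 (0.11 log units; within the scatter) in this assay. Within the data shown here, this is the first step in the set that can be read, and it shows that with the chloromethylbenzyl group held constant, removing the amino group from this position leaves the number indistinguishable from that of compound 1, so no effect of this change can be claimed. The chloro to hydrogen change that links compound 3 to compound 4 cannot be read, as compound 3 has no number, and no measurement is available that would explain the outcome at this position.

The compounds shown therefore leave open whether any group at this position can move the number beyond the scatter, since only amino and hydrogen have values there with this benzyl group, and a methoxy group, a methylamino group or a longer chain might behave differently. They also leave open what chloro itself contributes at this position, and whether the flat result for amino and hydrogen would hold in cells other than those of this assay.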